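A few compounds are considered here, and "the series" means these few. Any claim that something is new, unique, unknown or untested is made for them only; others in the source may bear on it.

Among the measured compounds shown here, in a functional assay on MIA PaCa-2 cells (Homo sapiens) for inhibition, read by MTT assay, with a stated time of 3 days (on this read-out lower numbers stand for stronger inhibition and higher numbers for weaker inhibition), compound 2 (`CCN(CC)S(=O)(=O)c1ccc(S(=O)(=O)N2CCC[C@@H](C(=O)N3CCC(COC)CC3)C2)cc1`) gives 50 nM, the lower of the two numbers so far, while compound 1 (`CCN(CC)S(=O)(=O)c1ccc(S(=O)(=O)N2CCC[C@@H](C(=O)NC3CCOCC3)C2)cc1`) gives 1350 nM. Compound 3 (`CCN(CC)S(=O)(=O)c1ccc(S(=O)(=O)N2CCC[C@@H](C(=O)N[C@H]3CC[C@@H](OC)CC3)C2)cc1`) differs from compound 2 on the carbonyl carbon: (4-methoxycyclohexyl)amino in place of 4-(methoxymethyl)piperidin-1-yl on a carbonyl carbon. For the measured compounds named here, only one measured step bears on this, the large 27-fold lower number from compound 1 to compound 2 (1.43 log units; beyond the scatter), which brought in 4-(methoxymethyl)piperidin-1-yl. Compound 3 gives that group up for an amino-linked ring, a feature shared with compound 1 at 1350 nM, so a higher number is expected, though probably not the full reversal. The expected move is a 6.0-fold higher number from compound 2 to compound 3 (0.78 log units; beyond the scatter). The estimated value for compound 3 is 300 nM, within a range of 70 nM to 1400 nM.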

Compound 3, half-maximal inhibitory concentration: 590 nM
Beside the measured number, compound 3's estimate is 2.0-fold (0.29 log units) below it, within the range that was stated.
By their numbers in this assay, from the lowest: compound 2; then compound 3; then compound 1.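

Rearranging the same atoms into (4-methoxycyclohexyl)amino on the carbonyl carbon gives a 12-fold higher number from compound 2 to compound 3 (1.07 log units; beyond the scatter) and so shows that the low number at this position does not follow from atom content alone. Among the two amino-linked compounds, 4-methoxycyclohexyl in place of oxan-4-yl on the amide-type nitrogen gives only a 2.3-fold lower number from compound 1 to compound 3 (0.36 log units; beyond the scatter) as a modest step, and both compounds stay higher than compound 2. Nothing given here explains these differences.

Still open, as far as these compounds go, is whether the low number of compound 2 depends on the piperidin-1-yl ring or on its methoxymethyl chain. A plain piperidin-1-yl or a 4-(hydroxymethyl)piperidin-1-yl on the carbonyl carbon would bear on that.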